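A few compounds are considered here, and "the series" means these few. Any claim that something is new, unique, unknown or untested is made for them only; others in the source may bear on it.

Measured so far in an ADME assay on CHO cells (Cricetulus griseus) for inhibition, read by MTT assay; a lower number here means a stronger inhibitor, a higher number a weaker inhibitor:

- compound 1 `Cc1cc(CNC(C)(C)C)c(O)c(Nc2nc3cc(F)c(F)cc3n2Cc2ccc(C(F)(F)F)cc2)c1`: 10000 nM
- compound 2 `CCN(CC)Cc1cccc(Nc2nc3ccccc3n2Cc2ccc(C#N)cc2)c1O`: a limit, > 50000 nM

Among the measured compounds shown here, compound 1 is the only member of the series with a number in this assay, where compound 1 gives 10000 nM. Compound 2 sits at the limit of this assay, reported as > 50000 nM and not as a number. For the measured compounds named here, nothing in the set joins these two by a single change, so no measured step exists to calibrate from; the one fixed point is the limit of > 50000 nM in this assay, at which 1 of the 2 values shown sits.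

Compound 3 `Cc1cc(CNC(C)(C)C)c(O)c(Nc2nc3cc(F)c(F)cc3[nH]2)c1` has not yet been tested. It differs from compound 1 by hydrogen in place of 4-(trifluoromethyl)benzyl on an aromatic nitrogen. Going by the values given here, no measured pair shows this change, so its size must be guessed. The expectation is a move toward a higher number in this assay, a weaker inhibitor, likely beyond the scatter, with a real chance that the result is only a limit. Compound 3 is estimated at 30000 nM, range 8000 nM to 100000 nM, an expected step of a 3.0-fold higher number from compound 1 to compound 3 (0.48 log units; beyond the scatter).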

Compound 3, half-maximal inhibitory concentration: 16700 nM
Estimate against measurement, compound 3: 1.8-fold (0.25 log units) above; low and high end bracket the measured number.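

Replacing 4-(trifluoromethyl)benzyl with hydrogen on the aromatic nitrogen gives, in this assay, a 1.7-fold higher number from compound 1 to compound 3 (0.22 log units; within the scatter), so the two compounds cannot be told apart here. On the core of compound 1, then, the reading in this assay does not depend on those 11 heavy atoms or on the aromatic ring they contain. Compound 2 remains the only compound reported as a limit and not as a number: the limit of > 50000 nM in this assay, at which 1 of the 3 values shown sits.

Open, on these data alone, is how a methyl group, an unsubstituted benzyl or a chain ending in a carboxylic acid would read on this nitrogen, since hydrogen and 4-(trifluoromethyl)benzyl are the only two substituents compared directly. Also open, as far as these compounds go, is whether the same replacement would leave the reading unchanged on a core carrying a diethylamino group, as in compound 2.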